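Replacing the 4-Chlorophenyl Group of Compound 2

The source may report more compounds than this note shows. Statements on the series, on what has been measured and on what is new or still open speak of the compounds shown alone.

In a functional assay on MCF7 cells (Homo sapiens) (on this read-out lower numbers stand for stronger inhibition of growth and higher numbers for weaker inhibition of growth), compound 1 (`O=S(=O)(/C=C/c1ccccc1)Cc1ccc(Nc2ncnc3ccccc23)cc1`) gives 74000 nM and compound 2 (`O=S(=O)(/C=C/c1ccc(Cl)cc1)Cc1ccc(Nc2ncnc3ccccc23)cc1`) gives 52000 nM on the same scale. Compound 2 therefore stands level with compound 1 within the scatter, and the two cannot be ranked. Among the compounds with values here, the one measured step, chloro in place of hydrogen on an aromatic carbon, is a 1.4-fold lower number from compound 1 to compound 2 (0.15 log units; within the scatter) and it is the only one that bears on what follows. Compound 3 (`O=S(=O)(/C=C/c1ccc(C(F)(F)F)cc1F)Cc1ccc(Nc2ncnc3ccccc23)cc1`) is still unmeasured and differs from compound 2 on a double-bonded chain carbon bound to a double-bonded chain carbon (2-fluoro-4-(trifluoromethyl)phenyl in place of 4-chlorophenyl on a double-bonded chain carbon bound to a double-bonded chain carbon). Within the data shown here, no measured compound carries fluoro or trifluoromethyl, so the data offer no direct guide. Substitution on this phenyl group has so far given only a 1.4-fold lower number from compound 1 to compound 2 (0.15 log units; within the scatter) and so no step beyond the scatter is expected in this assay for this change. An estimated 1.2-fold lower number from compound 2 to compound 3 (0.06 log units; within the scatter) is what the data support. Compound 3 is estimated at 45000 nM (expected range 18000 nM to 100000 nM).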

Compound 3, concentration for 50% growth inhibition: 100000 nM
Estimate against measurement, compound 3: 2.2-fold (0.35 log units) below; the range from low to high includes it.
By their numbers in this assay, from the lowest: compounds 2, 1 and 3 (each within the scatter of the next).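

In this assay, 2-fluoro-4-(trifluoromethyl)phenyl in place of 4-chlorophenyl gives a 1.9-fold higher number from compound 2 to compound 3 (0.28 log units; within the scatter), and the same group in place of phenyl gives a 1.4-fold higher number from compound 1 to compound 3 (0.13 log units; within the scatter). The place on a double-bonded chain carbon bound to a double-bonded chain carbon has thus taken a group of 11 heavy atoms, carrying both fluoro and trifluoromethyl, with no step beyond the scatter from either earlier group, so compound 1, compound 2 and compound 3 cannot be ranked. Nothing at hand offers an explanation for this result.

On these data alone, it remains open whether an amine, a carboxylic acid or a methoxy group at this place would give a step beyond the scatter. As far as these compounds go, it is equally open whether a change to the shared core would do so.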